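The source may hold more compounds than are shown below. What is called first, only, known or untested is meant among the compounds shown, and "the series" means these compounds.

Three compounds have so far been measured in a functional assay on the whole organism (blood, strain Wistar-Okamoto) with Rattus norvegicus as the target, with a stated time of 5 days; a higher number here means that more compound is needed for the effect, a lower number that less compound is needed:

compound 1 `CCC(CC)/N=C(\NC#N)Nc1cccnc1` gives 20 mg/kg;
compound 2 `CCC(CC)(CC)/N=C(\NC#N)Nc1cccnc1` gives 1 mg/kg;
compound 3 `CC(C)(C)CC(C)(C)/N=C(\NC#N)Nc1cccnc1` gives 50 mg/kg.

Among these three numbers compound 1 stands second highest. Its nearest neighbour is compound 3, which carries a higher number, and its furthest is compound 2, which carries a much lower one. Going by the values given here, the only step between measured compounds that differ in a single place is a 20-fold lower number from compound 1 to compound 2 (1.30 log units; beyond the scatter).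

Compound 4 `N#CN/C(=N\Cc1ccco1)Nc1cccnc1` is not yet measured. It differs from compound 1 in one place: (furan-2-yl)methyl in place of pentan-3-yl on a double-bonded nitrogen. Among the compounds with values here, no measured step concerns a change of this kind. The step of a 20-fold lower number from compound 1 to compound 2 (1.30 log units; beyond the scatter) describes a substituent added to the existing pentan-3-yl group, not the exchange of that whole group for (furan-2-yl)methyl, and the values of compound 1 and compound 3 show only that a different saturated chain on the same double-bonded nitrogen gave a higher number. With nothing that carries over, the author treats the change as open and expects compound 4 to remain close to compound 1. Compound 4 is therefore expected to show a change of a 1.5-fold higher number from compound 1 to compound 4 (0.18 log units; within the scatter) in this assay, which the author does not regard as a shift beyond the scatter. The estimate for compound 4 is 30 mg/kg, within a range from 8 mg/kg to 100 mg/kg.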

Compound 4, minimum effective dose: 20 mg/kg
Estimate against measurement, compound 4: 1.5-fold (0.18 log units) above, and the stated range covers the measured number.
By their numbers in this assay, from the lowest: compound 2; then compounds 1 and 4 (each within the scatter of the next); then compound 3.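

In this assay, going by these compounds alone, the exchange of pentan-3-yl for (furan-2-yl)methyl on the double-bonded nitrogen gives no change at the digits printed from compound 1 to compound 4 (within the scatter) and so shows that this position can carry a group with a five-membered aromatic ring and a hydrogen-bond acceptor, where the earlier compounds held only saturated chains. The same position had responded strongly to the addition of a single ethyl, with a 20-fold lower number from compound 1 to compound 2 (1.30 log units; beyond the scatter) in this measure, so the new result shows that not every change here moves the number, even when the whole group is exchanged. Nothing measured here accounts for the two groups giving the same number.

Going by these compounds, what a benzyl, a (thiophen-2-yl)methyl or a (tetrahydrofuran-2-yl)methyl group would give on this nitrogen stays open, and with it whether the oxygen or the aromatic ring of the entering group has any bearing on the number. Also open, on these data alone, is whether an ethyl added to the methyl carbon of (furan-2-yl)methyl would lower the number, as the added ethyl did in compound 2.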